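A few compounds are considered here, and "the series" means these few. Any claim that something is new, unique, unknown or untested is made for them only; others in the source may bear on it.

Working notes on the series. In a functional assay on K562 cells (Homo sapiens) for cytotoxicity, read by sulforhodamine B assay, with a stated time of 48 h, tested at 10 uM (on this read-out higher numbers stand for a weaker effect at the one concentration tested and lower numbers for a stronger effect), compound 2 `COc1ccc(C(=O)/C=C/c2cc(-c3cc(OC)c(OC)c(OC)c3)n[nH]2)cc1OC` gives -13%, the lowest of the two numbers at hand; the nearest is compound 1 `COc1cc(-c2cc(/C=C/C(=O)c3ccc(Cl)c(Cl)c3)[nH]n2)cc(OC)c1OC`, which in this assay gives 28%. Among the compounds with values here, the single measured step, a number 41 percentage points lower from compound 1 to compound 2 (beyond the scatter), is large and concerns the aryl group on the carbonyl carbon, the same ring that is altered in the next compound. Compound 3 `COc1ccc(C(=O)/C=C/c2cc(-c3cc(OC)c(OC)c(OC)c3)n[nH]2)cc1` differs from compound 2 by hydrogen in place of methoxy on an aromatic carbon. Within the data shown here, no measured step removes a methoxy from this ring, so the one step that bears on the region, a number 41 percentage points lower from compound 1 to compound 2 (beyond the scatter), shows only that this ring matters, not the direction of a smaller trim. The expected step is therefore modest: a number 10 percentage points higher from compound 2 to compound 3 (within the scatter), within the usual scatter. Compound 3 is estimated at -3%, with a range from -25% to 25%.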

Compound 3, a percentage reported as activity, at one concentration (the size of the read-out at that concentration, not a potency): -17%
Compound 3: middle estimate off by 14 percentage points, on the high side, and the stated range covers the measured number.
By their numbers in this assay, from the lowest: compounds 3 and 2 (each within the scatter of the next); then compound 1.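

In this assay, going from 3,4-dimethoxyphenyl to 4-methoxyphenyl gives a number 4 percentage points lower from compound 2 to compound 3 (within the scatter), so the methoxy ortho to a methoxy group can be replaced by hydrogen without a step beyond the scatter. Within the data shown here, the large step from the 3,4-dichlorophenyl compound also remains with only one methoxy on the ring: a number 45 percentage points lower from compound 1 to compound 3 (beyond the scatter) stands with a number 41 percentage points lower from compound 1 to compound 2 (beyond the scatter) as a second step beyond the scatter, and the second methoxy is not needed for it in this pair. No measurement at hand gives a reason for these steps.

As far as these compounds go, whether the remaining methoxy is itself needed stays open, as phenyl without any substituent would show. Also open, from the compounds shown here alone, is how an amine, a hydroxyl or a carboxylic acid in its place would read out in this assay on this ring.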